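Swapping Phenoxy for Dimethylamino on a Cytotoxic Scaffold

The source may hold more compounds than are shown below. What is called first, only, known or untested is meant among the compounds shown, and "the series" means these compounds.

Of the compounds shown here, three sharing one core have been tested in a functional assay on Malme-3M cells (Homo sapiens) for cytotoxicity, read by sulforhodamine B assay, with a stated time of 48 h, tested at 10 uM; on this read-out higher numbers stand for a weaker effect at the one concentration tested and lower numbers for a stronger effect. Compound 1 `COc1cc(C)cc(-c2c(-c3ccnc(-c4ccc(C(C)=O)cc4)c3)cnn2CC#N)c1` gives 43%, compound 2 `COc1cc(C)cc(-c2nn(CC#N)cc2-c2ccc(-c3cccc(C(C)=O)c3)nc2)c1` gives -1%, and compound 3 `Cc1cc(O)cc(-c2nn(CC#N)cc2-c2ccnc(-c3ccc(Oc4ccccc4)cc3)c2)c1` gives -72%. Compound 3 thus stands lowest of the three numbers, and both gaps lie beyond the scatter: the nearest is compound 2, and the furthest is compound 1. Each of these compounds differs from the others in more than one place, so no single-change step can be read among them.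

Compound 4 `Cc1cc(O)cc(-c2nn(CC#N)cc2-c2ccnc(-c3ccc(N(C)C)cc3)c2)c1` has not yet been measured. It differs from compound 3 in a single place: dimethylamino in place of phenoxy on an aromatic carbon The new group sits on an aromatic carbon of a six-membered aromatic ring of carbon only, para to a large group.

Going by the values given here, since compound 3 is the only compound carrying the phenoxy, and no step isolating this change is available, the outcome is uncertain. The step from compound 3 to compound 4 is expected to be a number 42 percentage points higher from compound 3 to compound 4 (beyond the scatter), a weakening of the effect in this assay. Compound 4 is accordingly estimated at -30%, within a range from -80% to 30%.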

Compound 4, a percentage reported as activity, at one concentration (the size of the read-out at that concentration, not a potency): -19%
For compound 4 the middle estimate is 11 percentage points below the measured one, within the range that was stated.
By their numbers in this assay, from the lowest: compound 3; then compound 4; then compound 2; then compound 1.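

In this assay, going by these compounds alone, the change from phenoxy to dimethylamino on an aromatic carbon, para to a large group, gives the first single-change reading: a number 53 percentage points higher from compound 3 to compound 4 (beyond the scatter). This step is large and beyond the scatter, so the read-out at this position clearly depends on which of these two groups it carries. The direction of the step is a weakening of the effect, yet the number stays below zero, with compound 3 at -72% and compound 4 at -19%. No measurement shown here bears on the reason for this step.

Within the data shown here, with only one step at this position, it remains open whether the ring of the phenoxy or the atom joined to the aromatic carbon accounts for the difference. On these data alone, how a methoxy group or a primary amine would read at this place also remains open.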